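The source may report more compounds than this note shows. Statements on the series, on what has been measured and on what is new or still open speak of the compounds shown alone.

Compound 3 `CCCCCCCCCCCCCCCCCCNC(=O)[C@@H](NC(=O)c1cc2ccccc2[nH]1)[C@@H](C)O` gives 81000 nM in a functional assay on A-431 cells (Homo sapiens) for cytotoxicity, read by MTT assay, with a stated time of 48 h (a lower number here means a stronger inhibitor, a higher number a weaker inhibitor), the highest of the three numbers in hand. Compound 2 `CCCCCCCCCCCCCCCCCCNC(=O)[C@@H](NC(=O)c1ccco1)[C@@H](C)O` gives 19900 nM in this assay, and compound 1 `CCCCCCCCCCCCNC(=O)[C@@H](NS(=O)(=O)c1ccc(C)cc1)[C@@H](C)O` gives 25200 nM. Compound 4 `CCCCCCCCCCCCCCCCCCNC(=O)[C@@H](NS(=O)(=O)c1ccc(C)cc1)[C@@H](C)O` arises from compound 3 by (4-methylphenyl)sulfonyl in place of (1H-indol-2-yl)carbonyl on an amine nitrogen. Among the measured steps only a 4.1-fold higher number from compound 2 to compound 3 (0.61 log units; beyond the scatter) touches the same nitrogen, and it tells that the indole carbonyl is the weaker of the two acyl groups tested on the octadecyl chain. Going by the values given here, compound 1 carries the same sulfonyl group on a dodecyl chain, and no step links it to compound 4. On these grounds compound 4 is expected to show a 3.4-fold lower number from compound 3 to compound 4 (0.53 log units; beyond the scatter), an estimated 24000 nM with a range from 10000 nM to 60000 nM.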

Compound 4, half-maximal inhibitory concentration: 34000 nM
Compound 4: the middle estimate sits 1.4-fold (0.15 log units) below what was measured, within the range that was stated.
By their numbers in this assay, from the lowest: compounds 2, 1 and 4 (each within the scatter of the next); then compound 3.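

In this assay the (4-methylphenyl)sulfonyl group on the amine nitrogen gives a 2.4-fold lower number from compound 3 to compound 4 (0.38 log units; beyond the scatter) and so outperforms the (1H-indol-2-yl)carbonyl group. Set against the (furan-2-yl)carbonyl group it gives a 1.7-fold higher number from compound 2 to compound 4 (0.23 log units; within the scatter) and cannot be told apart from it, so a sulfonyl group at this nitrogen does no worse than the better of the two carbonyl groups. Chain length can now be read as well: a 1.3-fold higher number from compound 1 to compound 4 (0.13 log units; within the scatter) shows that hexyl added to the dodecyl chain leaves the number within the scatter when this sulfonyl group is present.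

Going by these compounds, whether an acetyl or methanesulfonyl group on this nitrogen, or a chain longer than octadecyl, would shift the number remains open. Nothing given here accounts for these differences.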